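A few compounds are considered here, and "the series" means these few. Any claim that something is new, unique, unknown or untested is made for them only; others in the source may bear on it.

The three measured compounds, with their values in a functional assay on CCRF-CEM cells (Homo sapiens) for cytotoxicity, read by MTT assay, with a stated time of 72 h; on this read-out lower numbers stand for stronger inhibition of growth and higher numbers for weaker inhibition of growth:

compound 1, `COc1ccc(OC(=O)Nc2ccc([Se]C#N)cc2)cc1`: 13000 nM
compound 2, `CC(C)COC(=O)Nc1ccc([Se][Se]c2ccc(NC(=O)OCC(C)C)cc2)cc1`: 9800 nM
compound 3, `Cc1ccc(OC(=O)Nc2ccc([Se][Se]c3ccc(NC(=O)Oc4ccc(C)cc4)cc3)cc2)cc1`: 21400 nM

Compound 1 stands second highest of the three numbers. Its nearest neighbour is compound 2 and its furthest is compound 3, and both of those gaps lie within the usual scatter of this kind of measurement, so the three values cannot be put in any order with confidence.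

Compound 4, `Cc1ccc(OC(=O)Nc2ccc([Se]C#N)cc2)cc1`, differs from compound 1 in a single place: methyl in place of methoxy on an aromatic carbon. Among the measured compounds shown here, no pair of measured compounds shows this change on its own, so there is no measured step to lean on. Compound 3 does carry the methyl on the same kind of aryl carbamate, but it is a diselenide rather than a selenocyanate, and it differs from compound 2 in the carbamate as well, so neither comparison isolates the change. On this basis the step in this assay from compound 1 to compound 4 is expected to be small, with no clear direction and probably not beyond the scatter. Compound 4 is therefore estimated at 15000 nM, within a range of 6000 nM to 35000 nM, which corresponds to an expected step of a 1.2-fold higher number from compound 1 to compound 4 (0.06 log units; within the scatter).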

Compound 4, concentration for 50% growth inhibition: 17400 nM
Compound 4: the middle estimate sits 1.2-fold (0.06 log units) below what was measured; the measured number falls inside the stated range.
By their numbers in this assay, from the lowest: compounds 2, 1, 4 and 3 (each within the scatter of the next, the first and the last beyond it).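

In this assay, among the compounds shown here, the replacement of methoxy by methyl on an aromatic carbon, para to a large group, gives a 1.3-fold higher number from compound 1 to compound 4 (0.13 log units; within the scatter) and so provides the first measured step at this position. For the compounds shown here, the position therefore accepts the loss of the oxygen and its hydrogen-bond acceptor with no change that can be told from the scatter, which the earlier compounds, differing from one another in more than one place, could not show. Nothing measured here bears on why the step is this small.

From the compounds shown here alone, whether the number stays put with an amine, a carboxylic acid or a longer chain at this position remains open. So does whether the change from methoxy to methyl would give a similar step in the diselenide compounds.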